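From ((1H-benzimidazol-2-yl)methyl)sulfanyl to allylsulfanyl

The compounds below may be only part of what the source reports. "The series", "measured", "known", "first", "only" and "open" are said of these compounds alone.

In a functional assay on HGC-27 cells (Homo sapiens) for inhibition, read by MTT assay, with a stated time of 72 h (on this read-out higher numbers stand for weaker inhibition and lower numbers for stronger inhibition), compound 1 `Cc1cc(N2CC[C@@H](C)[C@@H](N(C)c3ncnc4[nH]ccc34)C2)n2nc(SCC3CC3)nc2n1` gives 21400 nM, and compound 3 `Cc1cc(N2CC[C@@H](C)[C@@H](N(C)c3ncnc4[nH]ccc34)C2)n2nc(SCc3ccc(F)cc3)nc2n1` gives 26000 nM. The step between them, a 1.2-fold higher number from compound 1 to compound 3 (0.08 log units; within the scatter), shows no separation. Compound 2 `Cc1cc(N2CC[C@@H](C)[C@@H](N(C)c3ncnc4[nH]ccc34)C2)n2nc(SCc3nc4ccccc4[nH]3)nc2n1` reads > 100000 nM, which is a limit and not a number: the limit of > 100000 nM in this assay, at which 1 of the 3 values shown sits. It stands weakest of the three, with an at least 4.6-fold higher number from compound 1 to compound 2 (0.66 log units; beyond the scatter) and an at least 3.8-fold lower number from compound 2 to compound 3 (0.58 log units; beyond the scatter).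

Compound 4 `C=CCSc1nc2nc(C)cc(N3CC[C@@H](C)[C@@H](N(C)c4ncnc5[nH]ccc45)C3)n2n1` brings vinyl in place of 1H-benzimidazol-2-yl on a saturated chain carbon bound to a sulfur. Both measured departures from the 1H-benzimidazol-2-yl group, to compound 1 and to compound 3, lowered the number, so a similar fall is expected. The expected step is an at least 4.0-fold lower number from compound 2 to compound 4 (0.60 log units; beyond the scatter). For compound 4 the estimate is 25000 nM, with an expected range of 10000 nM to 65000 nM.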

Compound 4, half-maximal inhibitory concentration: 35200 nM
Compound 4: middle estimate off by 1.4-fold (0.15 log units), on the low side; the measured number falls inside the stated range.
By their numbers in this assay, from the lowest: compounds 1, 3 and 4 (each within the scatter of the next). At a limit, above all of these: compound 2.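

Allyl gives a third, ring-free group at this position that cannot be told apart from the two ring-bearing ones, with a 1.6-fold higher number from compound 1 to compound 4 (0.22 log units; within the scatter) and a 1.4-fold higher number from compound 3 to compound 4 (0.13 log units; within the scatter). Among the four groups, only 1H-benzimidazol-2-yl stands apart, with an at least 2.8-fold lower number from compound 2 to compound 4 (0.45 log units; beyond the scatter). The reading of compound 2 is a limit, not a number: the limit of > 100000 nM in this assay, at which 1 of the 4 values shown sits.

From the compounds shown here alone, whether an amine or a carboxylic acid on this chain carbon would shift the number remains open. The compounds shown also leave open what in 1H-benzimidazol-2-yl sets it apart.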